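From 3-Hydroxypropyl to 2-Hydroxyethyl: Expected Cytotoxicity

The source may hold more compounds than are shown below. What is called first, only, known or untested is meant among the compounds shown, and "the series" means these compounds.

Within the data shown here, compound 2 `COc1nc2ccc(Br)cc2cc1C(c1ccccc1)n1cc(CCCO)nn1` gives 11.3% in an ADME assay on HeLa cells (Homo sapiens) for cytotoxicity, read by sulforhodamine B assay, with a stated time of 48 h, tested at 10 uM (a lower number here means less inhibition, a higher number more inhibition at the concentration tested (going by the name of the read-out)), the higher of the two numbers measured so far: compound 1 `CCCCCCCCc1cn(C(c2ccccc2)c2cc3cc(Br)ccc3nc2OC)nn1` gives 0.1%, and the step of a number 11.2 percentage points higher from compound 1 to compound 2 (beyond the scatter) came with hydroxy in place of pentyl on a saturated chain carbon. Compound 3 `COc1nc2ccc(Br)cc2cc1C(c1ccccc1)n1cc(CCO)nn1` differs from compound 2 by hydroxy in place of hydroxymethyl on a saturated chain carbon, two bonds along the chain from an aromatic carbon. Among the measured compounds shown here, no measured step trims a chain by one carbon in this way, so only the smallness of the change guides the expectation. For compound 3 an inhibition of 10% is estimated, with a range from 0% to 22%. The step of a number 1.3 percentage points lower from compound 2 to compound 3 (within the scatter) that this estimate implies is expected to stay within the usual scatter.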

Compound 3, a percentage reported as inhibition, at one concentration (the size of the read-out at that concentration, not a potency): 0.85%
The estimate for compound 3 lay 9.2 percentage points above the measured number, within the range that was stated.
By their numbers in this assay, from the lowest: compounds 1 and 3 (each within the scatter of the next); then compound 2.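

In this assay, trimming 3-hydroxypropyl to 2-hydroxyethyl shows that this position responds to a change of a single carbon (in numbers, a number 10.5 percentage points lower from compound 2 to compound 3 (beyond the scatter)). The hydroxy group alone therefore does not set the reading, as the two shorter-chain results differ and compound 3 cannot be told apart from the long-chain compound 1 (a number 0.8 percentage points higher from compound 1 to compound 3 (within the scatter)). Nothing available here explains why this one carbon matters. Still open, as far as these compounds go, is how a shorter hydroxymethyl chain would read in this assay. The same applies to an amine or a carboxylic acid in place of the hydroxy.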